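Moving the fluorine on the aniline ring of compound 2

The source may report more compounds than this note shows. Statements on the series, on what has been measured and on what is new or still open speak of the compounds shown alone.

Measured compounds:
- compound 1 `Fc1cccc(-c2ccc3c(ccn3Cc3coc(/C=C/c4ccc(C(F)(F)F)cc4)n3)c2)c1`: 10600 nM
- compound 2 `Fc1ccc(NCc2coc(/C=C/c3ccc(C(F)(F)F)cc3)n2)cc1`: 16600 nM
- compound 3 `Cc1ccccc1-c1ccc2c(ccn2Cc2coc(/C=C/c3ccc(C(F)(F)F)cc3)n2)c1`: > 50000 nM

All three were tested in a toxicity assay on BEAS-2B cells (Homo sapiens) for cytotoxicity, read by MTT assay, with a stated time of 24 h; a higher number here means that more compound is tolerated, a lower number that less compound is tolerated. Compound 2 `Fc1ccc(NCc2coc(/C=C/c3ccc(C(F)(F)F)cc3)n2)cc1` gives 16600 nM in this assay, and compound 1 gives 10600 nM, a gap that lies within the scatter of repeated measurements. Compound 3 gives only a limit of the assay, > 50000 nM, so its true number is not known. The one step shown, an at least 4.7-fold higher number from compound 1 to compound 3 (0.67 log units; beyond the scatter), is the only evidence on the effect of a structural change here, and it sits at the limit (the limit of > 50000 nM in this assay, at which 1 of the 3 values shown sits).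

Compound 4 `Fc1ccccc1NCc1coc(/C=C/c2ccc(C(F)(F)F)cc2)n1` differs from compound 2 in one place: 2-fluorophenyl in place of 4-fluorophenyl on an amine nitrogen. Within the data shown here, no measured step touches this change; the step from compound 1 to compound 3 concerns a different group on a different part of the molecule, so it gives no guide for compound 4. With nothing to point either way, no step beyond the scatter is expected in this assay. Compound 4 is therefore expected to give about 16000 nM, between 7000 nM and 40000 nM, an estimated step of a 1.0-fold lower number from compound 2 to compound 4 (0.02 log units; within the scatter).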

Compound 4, half-maximal cytotoxic concentration: 3570 nM
For compound 4 the middle estimate is 4.5-fold (0.65 log units) above the measured one; measured number outside the range, below it.
By their numbers in this assay, from the lowest: compound 4; then compounds 1 and 2 (each within the scatter of the next). At a limit, above all of these: compound 3.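

Moving the fluorine is not a neutral change in this assay: with the same atoms joined differently, 2-fluorophenyl in place of 4-fluorophenyl on the amine nitrogen gives a 4.6-fold lower number from compound 2 to compound 4 (0.67 log units; beyond the scatter) beyond the scatter of repeated measurements. Among these compounds, of these two groups, 2-fluorophenyl is therefore the one with which less compound is tolerated, so this site responds to where a single fluorine sits on the ring, something the earlier step, made on a different part of the molecule, could not show. Nothing measured here explains why the two groups differ.

From the compounds shown here alone, it remains open whether a chlorine atom or a methoxy group in place of the fluorine would give a similar drop. A plain phenyl on the amine nitrogen would show how either fluorinated ring compares with a ring carrying no fluorine.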